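This account rests on a few compounds, and the source may have more. Where it says the series, first, only, none or still open, it means among the compounds named here.

In a functional assay on PC-3 cells (Homo sapiens) for antiproliferative activity, read by sulforhodamine B assay, with a stated time of 48 h (a lower number here means a stronger inhibitor of growth, a higher number a weaker inhibitor of growth), compound 1 `O=C(/C=C/c1cccc(S(=O)(=O)c2ccc3ccccc3n2)c1)NO` gives 150 nM. Within the data shown here, the only other measured compound, compound 2 `COc1ccc2nc(S(=O)(=O)c3cccc(/C=C/C(=O)NO)c3)ccc2c1`, gives 280 nM, so the two stand within the usual scatter of each other and neither can be ranked above the other. Compound 3 `O=C(/C=C/c1cccc(S(=O)(=O)c2ccc3cccc(F)c3n2)c1)NO` has not been measured yet. It differs from compound 1 in one place: fluoro in place of hydrogen on an aromatic carbon.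

Among the measured compounds shown here, the only measured step that bears on this change is a 1.9-fold higher number from compound 1 to compound 2 (0.27 log units; within the scatter), which comes from methoxy in place of hydrogen on an aromatic carbon. Fluoro is a different group, so this single step is only a loose guide. On that guide, no shift beyond the scatter is expected in this assay. The expected move, a 1.1-fold higher number from compound 1 to compound 3 (0.05 log units; within the scatter), is small. For compound 3 the estimated value is 170 nM, with an expected range from 65 nM to 430 nM.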

Compound 3, concentration for 50% growth inhibition: 320 nM
Compound 3: middle estimate off by 1.9-fold (0.27 log units), on the low side; low and high end bracket the measured number.
By their numbers in this assay, from the lowest: compounds 1, 2 and 3 (each within the scatter of the next, the first and the last beyond it).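

Placing fluoro on this aromatic carbon, ortho to a fused ring, gives a 2.1-fold higher number from compound 1 to compound 3 (0.33 log units; beyond the scatter) in this assay, so growth inhibition is weaker. Unlike the step to the methoxy compound, a 1.9-fold higher number from compound 1 to compound 2 (0.27 log units; within the scatter), which stays within the scatter, this step shows that a substituent of a single heavy atom on the core of compound 1 can move the number measurably, though only modestly. No measurement shown here explains why this substitution has that effect.

From the compounds shown here alone, it remains open whether the loss belongs to fluoro itself or would follow any group placed on this carbon, which chloro, methyl or an amine at the same place could test. Going by these compounds, whether fluoro on another aromatic carbon of the core would give a similar step also remains open.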